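The source may report more compounds than this note shows. Statements on the series, on what has been measured and on what is new or still open speak of the compounds shown alone.

Within the data shown here, compound 1 `Cc1c(OCCCCOCOc2ccc(C(=O)O)cc2)ccc(C(=O)CC2CCCC2)c1O` is the only member of the series with a number: in an assay on HEK293 cells for positive allosteric modulation of metabotropic glutamate receptor 3 (Rattus norvegicus), read by thallium flux, with a stated time of 2.5 min (a lower number here means that less compound is needed, a higher number that more compound is needed for the effect), compound 1 gives 1910 nM. Compound 2 `COC(=O)c1ccc(OCCCCOc2ccc(C(=O)CC3CCCC3)c(C)c2C)cc1` carries no result in this assay, reported as "not determined" (no result reported). Compound 3 `Cc1ccc(C(=O)O)cc1OCCCCOc1ccc(C(=O)CC2CCCC2)c(O)c1C` is the next candidate for this assay and differs from compound 1 by 5-carboxy-2-methylphenyl in place of (4-carboxyphenoxy)methyl on an oxygen on a saturated carbon. Among the measured compounds shown here, no step between measured compounds is available to anchor the change, so a shift of about a 1.2-fold lower number from compound 1 to compound 3 (0.08 log units; within the scatter) is expected, that is none beyond the usual scatter in either direction. Compound 3 is therefore estimated at 1600 nM, with a range from 500 nM to 5000 nM.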

Compound 3, half-maximal effective concentration: > 10000 nM
Compound 3 was reported as a limit (the forecaster's own chance of this, stated with the estimate: 15%); at least 6.2-fold (0.79 log units) between middle value and limit.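

At the place on an oxygen on a saturated carbon, 5-carboxy-2-methylphenyl in place of (4-carboxyphenoxy)methyl is not a neutral exchange in this assay, with an at least 5.2-fold higher number from compound 1 to compound 3 (0.71 log units; beyond the scatter). Compound 3 gives > 10000 nM, which is a limit and not a number. The size of the step is therefore only a minimum, because compound 3 sits at that limit: the limit of > 10000 nM in this assay, at which 1 of the 3 values shown sits.

A single pair cannot separate the contribution of the ring methyl from that of the changed link to the ring. On these data alone, it also remains open whether a plain 4-carboxyphenyl or a tetrazole in place of the carboxylic acid would hold up at this place.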